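Replacing the Amide Side Chain with a Triazole Ring

A few compounds are considered here, and "the series" means these few. Any claim that something is new, unique, unknown or untested is made for them only; others in the source may bear on it.

Compound 1 `CC(C)Cn1c(=O)n(C)c(=O)c2nc(SCCCCO)c(Cc3cccc4ccccc34)nc21` gives 37 nM in a functional assay on Raji cells (Homo sapiens) for inhibition, read by MTT assay, with a stated time of 96 h; a higher number here means that more compound is needed for the effect, a lower number that less compound is needed.
Compound 2 `CC(C)Cn1c(=O)n(C)c(=O)c2nc(S(=O)(=O)CCCO)c(Cc3cccc4ccccc34)nc21` gives 3750 nM in this assay.
Compound 3 `CC(C)Cn1c(=O)n(C)c(=O)c2nc(C(=O)N(C)CCCO)c(Cc3cccc4ccccc34)nc21` gives > 10000 nM in this assay.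

Compound 3 stands at the weak end: its result is only a limit of the assay, not a number (the limit of > 10000 nM in this assay, at which 1 of the 3 values shown sits). Compound 4 `CC(C)Cn1c(=O)n(C)c(=O)c2nc(-c3[nH]nnc3CCCO)c(Cc3cccc4ccccc34)nc21` differs from it in one place: 4-(3-hydroxypropyl)-1H-1,2,3-triazol-5-yl in place of (3-hydroxypropyl)(methyl)carbamoyl on an aromatic carbon. Among the measured compounds shown here, no measured step involves a triazole, so the guide is indirect. Both changes away from the sulfanyl chain of compound 1 raised the number sharply, a 100-fold higher number from compound 1 to compound 2 (2.01 log units; beyond the scatter) and an at least 270-fold higher number from compound 1 to compound 3 (2.43 log units; beyond the scatter), and the carbamoyl was the weakest, an at least 2.6-fold higher number from compound 2 to compound 3 (0.42 log units; beyond the scatter). A ring with a hydroxypropyl chain attached directly to the core is a different kind of group again; a modest lowering from compound 3 is expected, an at least 2.0-fold lower number from compound 3 to compound 4 (0.30 log units; that floor lies within the scatter), with wide uncertainty. Compound 4 is therefore estimated at 5000 nM, expected between 500 nM and 30000 nM.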

Compound 4, half-maximal effective concentration: 6020 nM
Estimate against measurement, compound 4: 1.2-fold (0.08 log units) below; the measured number falls inside the stated range.
By their numbers in this assay, from the lowest: compound 1; then compounds 2 and 4 (each within the scatter of the next). At a limit, above all of these: compound 3.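

Putting a ring on this aromatic carbon does not recover the activity of the sulfanyl chain: a 160-fold higher number from compound 1 to compound 4 (2.21 log units; beyond the scatter). The triazole and the sulfonyl chain cannot be told apart here: a 1.6-fold higher number from compound 2 to compound 4 (0.21 log units; within the scatter). The step from the carbamoyl rests on a limit of the assay and gives only a floor: an at least 1.6-fold lower number from compound 3 to compound 4 (0.22 log units; that floor lies within the scatter).

Each replacement also carries a hydroxypropyl chain rather than a hydroxybutyl chain, so the linking group and the chain length remain unseparated. A (3-hydroxypropyl)sulfanyl group, or a 4-hydroxybutyl chain on the triazole, would separate them.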